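This account rests on a few compounds, and the source may have more. Where it says the series, first, only, none or still open, it means among the compounds named here.

Series notes. Within the data shown here, compound 2 `O=C(/C=C/c1ccc(O)c(O)c1)OCc1c(-c2ccccc2)no[n+]1[O-]` gives 2540 nM in a functional assay on NCI-H460 cells (Homo sapiens) for cytotoxicity, read by resazurin assay, with a stated time of 72 h (a lower number here means a stronger inhibitor, a higher number a weaker inhibitor), the lowest of the three numbers so far. Compound 1 `COc1cc(/C=C/C(=O)Oc2ccc(OCc3c(-c4ccccc4)no[n+]3[O-])cc2)ccc1O` gives 15800 nM in this assay, and compound 3 `COc1cc(/C=C/C(=O)OCCCO[N+](=O)[O-])ccc1O` gives 29000 nM there; both gaps to compound 2 lie beyond the scatter, so compound 2 stands as the strongest inhibitor of the three.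

The next compound, compound 4 `COc1cc(/C=C/C(=O)OCc2c(-c3ccccc3)no[n+]2[O-])ccc1O`, has not been measured in this assay. Against compound 2 it differs in one place: methyl in place of hydrogen on an oxygen on an aromatic ring. Among the measured compounds shown here, no step between measured compounds carries this same change, so its size cannot be read off directly.

A move toward a weaker number is nevertheless expected, because compound 1 gives 15800 nM and compound 3 gives 29000 nM, the two compounds that carry the 4-hydroxy-3-methoxyphenyl group. The expected step from compound 2 to compound 4 is a 3.1-fold higher number from compound 2 to compound 4 (0.50 log units; beyond the scatter). For compound 4 the estimate in this assay is 8000 nM, with a range from 3000 nM to 25000 nM; a further measurement is needed to fix it.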

Compound 4, half-maximal inhibitory concentration: 7030 nM
For compound 4 the middle estimate is 1.1-fold (0.06 log units) above the measured one; measured number inside the range.
By their numbers in this assay, from the lowest: compound 2; then compound 4; then compounds 1 and 3 (each within the scatter of the next).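

In this assay, the change from hydroxy to methoxy on an oxygen on an aromatic ring, with the rest of the molecule held constant, gives a 2.8-fold higher number from compound 2 to compound 4 (0.44 log units; beyond the scatter) as its first direct reading. The earlier compounds shown here differed from one another in more than one place, so this single pair is what isolates the change and shows that the 3,4-dihydroxyphenyl group and the 4-hydroxy-3-methoxyphenyl group are not interchangeable here. No supporting data are available to explain the size of this step.

As far as these compounds go, whether a step of this size carries over to other ester portions, such as the nitrate-bearing propyl chain of compound 3, remains open. Also open, from the compounds shown here alone, is how an ethoxy group, a longer alkoxy chain or an amine would compare with the methoxy group in this place.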